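Isopropyl for Phenethyl at the Amine-Bearing Carbon

This account rests on a few compounds, and the source may have more. Where it says the series, first, only, none or still open, it means among the compounds named here.

Compound 1 `O=C(N[C@@H](CCc1ccccc1)CNc1ccc(OC(F)(F)F)cc1)[C@@H](CC(=O)N1CCOCC1)CC1CCCCC1`: 18 nM
Compound 2 `C[C@@H](CNc1ccc(OC(F)(F)F)cc1)NC(=O)[C@@H](CC(=O)N1CCOCC1)CC(C)(C)C`: 408 nM
Compound 3 `C[C@@H](CNc1ccc(OC(F)(F)F)cc1)NC(=O)[C@H](CCC(C)(C)C)CC(=O)N1CCOCC1`: 70 nM

In an assay on isolated protein for inhibition of cathepsin S (Homo sapiens) (on this read-out higher numbers stand for weaker inhibition and lower numbers for stronger inhibition), compound 1 gives the lowest of the three numbers, with compound 3 nearest and compound 2 furthest. Going by the values given here, the only measured single step, a 5.8-fold lower number from compound 2 to compound 3 (0.77 log units; beyond the scatter), concerns a change at a different place and so does not bear directly on the change considered here. Compound 4 `CC(C)[C@@H](CNc1ccc(OC(F)(F)F)cc1)NC(=O)[C@@H](CC(=O)N1CCOCC1)CC1CCCCC1` differs from compound 1 by isopropyl in place of phenethyl on a saturated chain carbon bound to an amide-type nitrogen and a saturated chain carbon. Compounds 2 and 3, which carry a methyl at that carbon, both give higher numbers than compound 1, so a smaller group at this position is expected to weaken inhibition somewhat. Compound 4 is therefore estimated at 45 nM, between 12 nM and 150 nM, a step of a 2.5-fold higher number from compound 1 to compound 4 (0.40 log units; beyond the scatter) expected in this assay.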

Compound 4, inhibition constant: 11 nM
Estimate against measurement, compound 4: 4.1-fold (0.61 log units) above; measured number outside the range, below it.
By their numbers in this assay, from the lowest: compounds 4 and 1 (each within the scatter of the next); then compound 3; then compound 2.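

In this assay, isopropyl in place of phenethyl on a saturated chain carbon bound to an amide-type nitrogen and a saturated chain carbon gives a 1.6-fold lower number from compound 1 to compound 4 (0.21 log units; within the scatter). This position therefore tolerates the loss of the six-membered aromatic ring and a drop from 8 heavy atoms to 3 without a change in inhibition that exceeds the scatter. No measurement shown accounts for this result. No compound shown isolates a methyl at this carbon, as compounds 2 and 3 each differ from compound 4 in a second place. From the compounds shown here alone, how a benzyl group or a chain ending in an amine would read here remains open.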